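The source may report more compounds than this note shows. Statements on the series, on what has been measured and on what is new or still open speak of the compounds shown alone.

In an in vitro ADME assay on microsomes (Mus musculus) for metabolic stability (on this read-out lower numbers stand for a shorter-lived compound and higher numbers for a longer-lived compound), compound 1 `CNC(=O)Nc1ccc(-c2nc(N3CC4CCC(C3)O4)c3cnn(C)c3n2)cc1` gives > 0.5 h, which is a limit and not a number. Compound 2 `O=C(Nc1ccc(-c2nc(N3CC4CCC(C3)O4)c3cnn(C4CCC5(CC4)OCCO5)c3n2)cc1)Nc1cccnc1` gives > 0.5 h, also a limit. Compound 3 `CCNC(=O)Nc1ccc(-c2nc(N3CC4CCC(C3)O4)c3cnn(C4CCC5(CC4)OCCO5)c3n2)cc1` gives 0.45 h. Within the data shown here, the only measured step, an at least 1.1-fold lower number from compound 2 to compound 3 (0.04 log units; that floor lies within the scatter), concerns a different place in the molecule, so it offers little guidance here. Compound 4 `CNC(=O)Nc1ccc(-c2nc(N3CC4CCC(C3)O4)c3cnn([C@H]4CC[C@H](O)CC4)c3n2)cc1` differs from compound 1 by 4-hydroxycyclohexyl in place of methyl on an aromatic nitrogen. Among the measured compounds shown here, no measured step covers this change, and its size stays uncertain because of the limit of > 0.5 h in this assay, at which 2 of the 3 values shown sit. The nearest guide is compound 3 at 0.45 h, which also carries a ring-bearing group on that nitrogen. The expected change is small: an at least 1.2-fold lower number from compound 1 to compound 4 (0.09 log units; that floor lies within the scatter). For compound 4, the estimated half-life is 0.4 h, with an expected range of 0.2 h to 0.8 h.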

Compound 4, half-life: > 0.5 h
Compound 4 ended at the assay's limit; the forecaster's own chance of this, stated with the estimate: 40%; at least 1.2-fold (0.09 log units) between middle value and limit.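

Among these compounds, no step from compound 1 to compound 4 can be read in this assay, because both stop at a limit: the limit of > 0.5 h in this assay, at which 3 of the 4 values shown sit. From the compounds shown here alone, how far 4-hydroxycyclohexyl in place of methyl shifts the half-life, and in which direction, stays open.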